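A Second Chloro on the Fused Core: Compound 4

This account rests on a few compounds, and the source may have more. Where it says the series, first, only, none or still open, it means among the compounds named here.

Measured compounds:
compound 1 `ClCc1cccc(Cn2cnc3ncnc(Cl)c32)c1` gives 29500 nM in a functional assay on EKVX cells (Homo sapiens) for cytotoxicity, read by sulforhodamine B assay, with a stated time of 48 h; a higher number here means a weaker inhibitor of growth, a lower number a stronger inhibitor of growth
compound 2 `ClCc1ccccc1Cn1cnc2ncnc(Cl)c21` gives 17800 nM in this assay
compound 3 `ClCc1cccc(Cn2cnc3nc(Cl)nc(Cl)c32)c1` gives 2130 nM in this assay

Compound 2 sits close to compound 1, the two values lying within the scatter of each other, while compound 3 lies well below both. The unmeasured compound 4 `ClCc1ccccc1Cn1cnc2nc(Cl)nc(Cl)c21` arises from compound 2 by one change: chloro in place of hydrogen on an aromatic carbon. The same change has been measured once, on the isomer carrying the chloromethyl group at a different position of the benzyl ring, as the step from compound 1 to compound 3: a 14-fold lower number from compound 1 to compound 3 (1.14 log units; beyond the scatter). Among the compounds with values here, that step is the only one that bears on the question, and it is large, so a downward step of comparable size is expected here, with some allowance for the fact that only one example exists and that compound 2 and compound 1 differ in where the chloromethyl sits. For compound 4 the number is therefore estimated at 1500 nM, with a range from 500 nM to 5000 nM. This estimate means an expected step from compound 2 to compound 4 of a 12-fold lower number from compound 2 to compound 4 (1.07 log units; beyond the scatter).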

Compound 4, concentration for total growth inhibition: 3230 nM
Beside the measured number, compound 4's estimate is 2.2-fold (0.33 log units) below it; the range from low to high includes it.
By their numbers in this assay, from the lowest: compounds 3 and 4 (each within the scatter of the next); then compounds 2 and 1 (each within the scatter of the next).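

In this assay, chloro in place of hydrogen on an aromatic carbon, between two ring nitrogen atoms, now gives a second lower number, a 5.5-fold lower number from compound 2 to compound 4 (0.74 log units; beyond the scatter), so the change no longer rests on a single example. It has now been read with the chloromethyl group at two different places on the benzyl ring, and the two steps do not separate: the same change on two cores in this assay, a 14-fold lower number (1.14 log units; beyond the scatter) from compound 1 to compound 3 and a 5.5-fold lower number (0.74 log units; beyond the scatter) from compound 2 to compound 4, 2.5-fold (0.40 log units) apart, within the scatter of two such steps. Compounds 3 and 4, which both carry the added chloro, lie within the scatter of each other, as do compounds 1 and 2, which both lack it, so among these four compounds the added chloro separates the values and the place of the chloromethyl group does not.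

Chloro is the only group shown at this position, which leaves open whether an amine, a methoxy group or a fluoro there would lower the number in the same way. Every compound shown also carries the chloromethyl group and the other chloro on the core, so what a plain methyl in place of the chloromethyl group, or an amine in place of that other chloro, would do remains unknown.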